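The compounds below may be only part of what the source reports. "The series", "measured", "known", "first", "only" and "open" are said of these compounds alone.

Compound 1 `CC(=O)OC[C@H]1O[C@@H](n2cc(CN3C(=O)/C(=C/c4ccc(C)cc4)c4ccccc43)nn2)[C@H](OC(C)=O)[C@@H](OC(C)=O)[C@@H]1OC(C)=O`, in an ADME assay on NIH3T3 cells (Homo sapiens) for cytotoxicity, read by sulforhodamine B assay, with a stated time of 48 h; a lower number here means a stronger inhibitor, a higher number a weaker inhibitor: 73300 nM
Compound 2 `CC(=O)OC[C@H]1O[C@@H](n2cc(CN3C(=O)/C(=C/c4ccc(N(C)C)cc4)c4ccccc43)nn2)[C@H](OC(C)=O)[C@@H](OC(C)=O)[C@@H]1OC(C)=O`, in this assay: 12700 nM
Compound 3 `CC(=O)OC[C@H]1O[C@@H](n2cc(CN3C(=O)/C(=C\c4ccc5ccccc5c4)c4ccccc43)nn2)[C@H](OC(C)=O)[C@@H](OC(C)=O)[C@@H]1OC(C)=O`, in this assay: 80000 nM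

Compound 3 holds the highest of the three numbers. Its nearest neighbour is compound 1, whose value lies within the usual scatter of it, so the two cannot be ordered. Compound 2 stands further away, beyond the scatter, with the lowest number of the set.

Compound 4 `CC(=O)OC[C@H]1O[C@@H](n2cc(CN3C(=O)/C(=C/c4ccc5ccccc5c4)c4ccccc43)nn2)[C@H](OC(C)=O)[C@@H](OC(C)=O)[C@@H]1OC(C)=O` is not yet measured. The change from compound 3 to compound 4 is the two compounds have the same atoms and bonds and differ only in configuration as drawn: 1 of 6 stereo elements differ; a double bond is drawn Z in compound 3 and E in compound 4.

Going by the values given here, only one measured step exists, a 5.8-fold lower number from compound 1 to compound 2 (0.76 log units; beyond the scatter), and it concerns a substituent swap on an aromatic carbon, not a change of double-bond geometry. Among the compounds with values here, no measured pair therefore bears directly on the step from compound 3 to compound 4, and the data give no indication of its direction. In the absence of any relevant precedent, compound 4 is expected to land close to compound 3, with a step of a 1.1-fold lower number from compound 3 to compound 4 (0.06 log units; within the scatter) that stays within the scatter. Within the data shown here, the estimate for compound 4 in this assay is 70000 nM, with a range from 25000 nM to 200000 nM, kept wide because a geometric change has no measured counterpart here.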

Compound 4, half-maximal inhibitory concentration: 28400 nM
For compound 4 the middle estimate is 2.5-fold (0.39 log units) above the measured one; measured number inside the range.
By their numbers in this assay, from the lowest: compound 2; then compound 4; then compounds 1 and 3 (each within the scatter of the next).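

In this assay, going by these compounds alone, changing the double-bond geometry alone moves the number, a result the earlier compounds could not show: a 2.8-fold lower number from compound 3 to compound 4 (0.45 log units; beyond the scatter). With no other structural change in the pair, this step can be assigned only to the configuration of that double bond: the fact that compounds 3 and 4 differ only in the configuration as drawn. With the geometry held as drawn in compound 4, the group on the double-bonded chain carbon also matters: naphthalen-2-yl in place of 4-methylphenyl gives a 2.6-fold lower number from compound 1 to compound 4 (0.41 log units; beyond the scatter), whereas naphthalen-2-yl in place of 4-(dimethylamino)phenyl gives a 2.2-fold higher number from compound 2 to compound 4 (0.35 log units; beyond the scatter), which puts the naphthalen-2-yl compound behind the 4-(dimethylamino)phenyl compound and ahead of the 4-methylphenyl compound in this order of numbers.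

The compounds shown leave open whether double-bond geometry shifts the number in the same direction or by a similar amount when 4-methylphenyl or 4-(dimethylamino)phenyl is on the chain carbon, as the naphthalen-2-yl pair is the only geometric pair here. They also leave open how an aryl group bearing a carboxylic acid or a primary amine would read in this assay.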